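Swapping methylsulfonyl for tetrazolyl: half-life in rat

A few compounds are considered here, and "the series" means these few. Any claim that something is new, unique, unknown or untested is made for them only; others in the source may bear on it.

Compound 1 `CC(C)c1noc(N2CCC([C@H]3C[C@H]3COCc3ccc(S(C)(=O)=O)cc3F)CC2)n1`: 2.2 h
Compound 2 `CC(C)c1noc(N2CCC([C@H]3C[C@H]3COCc3ccc(-n4cnnn4)cc3F)CC2)n1`: 1.4 h
Compound 3 `COCc1cnc(N2CCC([C@H]3C[C@H]3COCc3ccc(S(C)(=O)=O)c(F)c3)CC2)nc1`: 1.2 h

All three were measured in an ADME assay on the whole organism (strain Wistar Han) for metabolic stability, with Rattus norvegicus as the target, read by LC-MS, at a dose of 0.5 mg/kg by the intravenous route; a lower number here means that the compound disappears faster, a higher number that the compound lasts longer. Compounds 1 and 2 share one core and differ in a single place: 1H-tetrazol-1-yl in place of methylsulfonyl on an aromatic carbon. That change gave a 1.6-fold lower number from compound 1 to compound 2 (0.20 log units; within the scatter). Compound 4 `COCc1cnc(N2CCC([C@H]3C[C@H]3COCc3ccc(-n4cnnn4)c(F)c3)CC2)nc1` is not yet measured; it stands to compound 3 as compound 2 stands to compound 1, namely (1H-tetrazol-1-yl in place of methylsulfonyl on an aromatic carbon). The difference between the two cores is not broken down here. The two places are not alike word for word: in compound 2 the entering group sits meta to a fluoro group, in compound 4 it sits ortho to a fluoro group, so this is the same kind of change rather than the same change. The expected step is a 1.5-fold lower number from compound 3 to compound 4 (0.18 log units; within the scatter), estimated because the matching change gave a 1.6-fold lower number from compound 1 to compound 2 (0.20 log units; within the scatter), a step that itself lies within the scatter. Compound 4 is therefore expected to give about 0.8 h in this assay, most likely between 0.4 h and 1.6 h.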

Compound 4, half-life in the Rattus norvegicus assay: 3 h
Estimate against measurement, compound 4: 3.8-fold (0.57 log units) below, outside the stated range (above it).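

In the Rattus norvegicus assay, compound 3 gives 1.2 h and compound 4 gives 3 h; putting 1H-tetrazol-1-yl in place of methylsulfonyl gave a 2.5-fold higher number from compound 3 to compound 4 (0.40 log units; beyond the scatter), so the change did not carry over from one core to the other with the same size or direction: the same change on two cores in the Rattus norvegicus assay, a 1.6-fold lower number (0.20 log units; within the scatter) from compound 1 to compound 2 and a 2.5-fold higher number (0.40 log units; beyond the scatter) from compound 3 to compound 4, 3.9-fold (0.59 log units) apart, beyond the scatter of two such steps. Within the data shown here, this shows that, in this series, the step seen on the core of compound 1 is a poor guide to the step on the core of compound 3, but it does not show why, as the two pairs differ both in the core and in the place of the fluoro group, and each core offers only one pair. In a physicochemical assay for solubility, in simulated intestinal fluid, measured as kinetic solubility, at pH 6.5 (on this read-out higher numbers stand for higher solubility and lower numbers for lower solubility), compound 3 gives 155000 nM and compound 4 gives 133000 nM; the same change gave a 1.2-fold lower number from compound 3 to compound 4 (0.07 log units; within the scatter), so the two compounds cannot be told apart on that read-out.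

The compounds shown leave open whether other groups in the same place on the core of compound 3, such as a nitrile or a carboxylic acid, would also give a longer half-life. They also do not separate the place of the fluoro group from the rest of the core as the source of the gap between the two steps.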